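Cyano for fluoro on the aryl urea of compound 3

The source may report more compounds than this note shows. Statements on the series, on what has been measured and on what is new or still open speak of the compounds shown alone.

Compound 1, `N#Cc1cccc(NC(=O)N(CCN2CC[C@@H](O)C2)C2CC[C@]3(c4cccc(C#N)c4)CC3C2)c1`: 92 nM
Compound 2, `CC(C)N(CCN(C(=O)Nc1ccc(F)c(Cl)c1)C1CC[C@]2(c3cccc(C#N)c3)CC2C1)C(C)C`: 4.98 nM
Compound 3, `CC(C)N(CCN(C(=O)Nc1cccc(F)c1)C1CC[C@]2(c3cccc(C#N)c3)CC2C1)C(C)C`: 2.1 nM

In a functional assay for antagonist activity at melanin-concentrating hormone receptor 1 (Homo sapiens) (on this read-out lower numbers stand for stronger inhibition and higher numbers for weaker inhibition), compound 3 gives the lowest number of the three, with compound 2 next at a 2.4-fold lower number from compound 2 to compound 3 (0.38 log units; beyond the scatter) and compound 1 far behind. Compound 4, `CC(C)N(CCN(C(=O)Nc1cccc(C#N)c1)C1CC[C@]2(c3cccc(C#N)c3)CC2C1)C(C)C`, carries the change (cyano in place of fluoro on an aromatic carbon). For the measured compounds named here, no measured step shows this exact swap with the same amine; the only aryl step, a 2.4-fold lower number from compound 2 to compound 3 (0.38 log units; beyond the scatter), was modest, while compound 1, which also bears a cyanophenyl urea but a different amine, sits at 92 nM. A modest step is therefore expected, likely toward a somewhat higher number, a 2.1-fold higher number from compound 3 to compound 4 (0.33 log units; beyond the scatter). Compound 4 is estimated at 4.5 nM, within 1.5 nM to 14 nM.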

Compound 4, inhibition constant: 7.6 nM
The estimate for compound 4 lay 1.7-fold (0.23 log units) below the measured number; the measured number falls inside the stated range.
By their numbers in this assay, from the lowest: compound 3; then compounds 2 and 4 (each within the scatter of the next); then compound 1.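

In this assay the position on the aryl urea does respond to this swap, with cyano in place of fluoro giving a 3.6-fold higher number from compound 3 to compound 4 (0.56 log units; beyond the scatter) on this ring, while a 1.5-fold higher number from compound 2 to compound 4 (0.18 log units; within the scatter) stays within the scatter. With the 3-cyanophenyl urea held constant, the amine end moves the number further, as a 12-fold lower number from compound 1 to compound 4 (1.08 log units; beyond the scatter) comes with diisopropylamino in place of 3-hydroxypyrrolidin-1-yl. Nothing at hand explains either step. Still open, on these data alone, is how a methoxy group or a lone chlorine would fare at this position, and whether a 3-hydroxypyrrolidin-1-yl compound would follow the same fluoro-to-cyano step.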